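Replacing cyano with methoxy: what to expect for compound 4

The source may report more compounds than this note shows. Statements on the series, on what has been measured and on what is new or still open speak of the compounds shown alone.

In a functional assay on HUVEC cells (Homo sapiens) for inhibition, with a stated time of 4 days (on this read-out lower numbers stand for stronger inhibition and higher numbers for weaker inhibition), the three measured compounds give these values:
- compound 1 `COc1ccc(C(N)=O)cc1/C=C/c1ccc(C(F)(F)F)cc1` gives 880 nM
- compound 2 `COc1ccc(C(N)=O)cc1/C=C/c1ccc(C)cc1` gives 1600 nM
- compound 3 `COc1ccc(C(N)=O)cc1/C=C/c1ccc(C#N)cc1` gives 3100 nM

Compound 3 stands clearly apart from only one of the other two. The data show a 3.5-fold higher number from compound 1 to compound 3 (0.55 log units; beyond the scatter), but only a 1.9-fold higher number from compound 2 to compound 3 (0.29 log units; within the scatter).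

Compound 4 `COc1ccc(/C=C/c2cc(C(N)=O)ccc2OC)cc1` keeps the shared core and carries methoxy in place of cyano on an aromatic carbon, para to a large group: methoxy in place of cyano on an aromatic carbon.

Among the compounds with values here, no measured compound carries methoxy at this place, so the swaps among the other groups there are the only guide. The largest, a 3.5-fold higher number from compound 1 to compound 3 (0.55 log units; beyond the scatter), is modest, while a 1.8-fold higher number from compound 1 to compound 2 (0.26 log units; within the scatter). Both steps that end on cyano raise the number, so a small move away from the value of compound 3 is a reasonable guess. Expected in this assay is a 1.8-fold lower number from compound 3 to compound 4 (0.26 log units; within the scatter), which means a lower number, about as large as the steps seen so far. For compound 4 the estimated value is 1700 nM, with an expected range of 600 nM to 4500 nM.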

Compound 4, half-maximal inhibitory concentration: 8800 nM
Estimate against measurement, compound 4: 5.2-fold (0.71 log units) below; the whole stated range lies below it.
By their numbers in this assay, from the lowest: compounds 1, 2 and 3 (each within the scatter of the next, the first and the last beyond it); then compound 4.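

In this assay methoxy stands clearly apart from every other group shown at this place, with a 2.8-fold higher number from compound 3 to compound 4 (0.45 log units; beyond the scatter) and a 5.5-fold higher number from compound 2 to compound 4 (0.74 log units; beyond the scatter) and a 10-fold higher number from compound 1 to compound 4 (1.00 log units; beyond the scatter) as its steps, all beyond the scatter. The choice of group here can therefore matter more than the three earlier compounds suggested, and compound 4 now has the highest number of the set. Cyano and methoxy match in heavy-atom count and hydrogen-bond acceptor count, yet this match does not give matching numbers, and nothing available here bears on the reason for the difference.

On these data alone, it remains open whether the high number is particular to methoxy or extends to related groups such as ethoxy or hydroxyl. An amine or a halogen such as chlorine at this place would also test how far the trend reaches.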